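This account rests on a few compounds, and the source may have more. Where it says the series, first, only, none or still open, it means among the compounds named here.

Of the compounds shown here, three on a shared core have been read so far. Compound 1 `C(=C/c1nc(Nc2ccccc2)c2sccc2n1)\c1ccccc1` reads > 1000000 nM in a functional assay on L02 cells (Homo sapiens) for inhibition, read by Griess assay, with stated times of 1 h and 24 h (on this read-out higher numbers stand for weaker inhibition and lower numbers for stronger inhibition), and this is a limit of the assay. Compound 2 `Brc1ccc(Nc2nc(/C=C/c3ccccc3)nc3ccsc23)cc1` reads > 1000000 nM in this assay and this too is a limit. Compound 3 `COc1ccc(Nc2nc(/C=C/c3ccccc3)nc3ccsc23)cc1` reads > 1000000 nM in this assay and this again is a limit, so compound 3 stands on no number, and the two other values beside it are limits as well.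

The change to compound 4 `FC(F)(F)c1ccc(Nc2nc(/C=C/c3ccccc3)nc3ccsc23)cc1` comes to trifluoromethyl in place of methoxy on an aromatic carbon in all: trifluoromethyl in place of methoxy on an aromatic carbon, para to a large group. Among the measured compounds shown here, three measured steps bear on it, all at that same place. There is a step that the two limits leave unreadable from compound 1 to compound 2 for bromo in place of hydrogen, a step that the two limits leave unreadable from compound 1 to compound 3 for methoxy in place of hydrogen and a step that the two limits leave unreadable from compound 2 to compound 3 for methoxy in place of bromo. None of them has a readable size. Because the limit of > 1000000 nM in this assay, at which 3 of the 3 values shown sit, holds for compound 1, compound 2 and compound 3 alike, no step beyond the scatter is expected in this assay and no direction can be named. The estimated step is a number no higher from compound 3 to compound 4 (the limit leaves the size open) and it is expected to stay small. For compound 4 the estimate is 1000000 nM with an expected range from 300000 nM to 3000000 nM and the assay may well report only a limit again.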

Compound 4, half-maximal inhibitory concentration: > 1000000 nM
Compound 4: a limit, no number; the forecaster's own chance of this, stated with the estimate: 80%; the middle value lies on the limit itself.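

Compound 4 reads > 1000000 nM in this assay, and this is a limit of the assay. No step among compound 1, compound 2, compound 3 and compound 4 can be read, because all of them sit at the same limit: the limit of > 1000000 nM in this assay, at which 4 of the 4 values shown sit.

The compounds shown leave open whether any group at this place gives a readable inhibition in this assay.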